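Side-chain exchange from compound 3 to compound 4

A few compounds are considered here, and "the series" means these few. Any claim that something is new, unique, unknown or untested is made for them only; others in the source may bear on it.

Values so far in an ADME assay on microsomes from liver (Homo sapiens) for metabolic stability, using NADPH, with a stated time of 10 min (on this read-out higher numbers stand for a more stable compound and lower numbers for a less stable compound), are as follows:
- compound 1 `NCCCCN(C[C@H]1Cc2nccnc2CN1)[C@H]1CCCc2cccnc21` gives 84%
- compound 2 `CN(C[C@@H]1Cc2ncccc2CN1)[C@H]1CCCc2cccnc21` gives 100%
- compound 3 `NC/C=C\CN(C[C@H]1Cc2ncccc2CN1)[C@H]1CCCc2cccnc21` gives 85%

Compound 3 at 85% sits within the scatter of compound 1 at 84% in this assay and cannot be ranked against it. Compound 2 at 100% stands higher than compound 3 by more than the scatter.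

The next compound is compound 4 `CN(C)CCCCN(C[C@H]1Cc2ncccc2CN1)[C@H]1CCCc2cccnc21` and its difference from compound 3 is as follows: 3-(dimethylamino)propyl in place of 3-aminoprop-1-en-1-yl on a saturated chain carbon bound to an amine nitrogen with 3-(dimethylamino)propyl in place of 3-aminoprop-1-en-1-yl on a saturated chain carbon bound to an amine nitrogen. Among the compounds with values here, the series holds no measured step for this change, so the expectation rests only on the values of compound 3 and compound 1. A small drop that stays within the scatter is expected, and a number 7 percentage points lower from compound 3 to compound 4 (within the scatter) is the estimated size of it. In this assay the estimate for compound 4 is 78% with an expected range from 58% to 94% as the likely span.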

Compound 4, percent of the compound remaining: 100%
For compound 4 the middle estimate is 22 percentage points below the measured one; measured number above the stated range.
By their numbers in this assay, from the lowest: compounds 1 and 3 (each within the scatter of the next); then compounds 2 and 4 (each within the scatter of the next).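

In this assay, the side chain at this place, on a saturated chain carbon bound to an amine nitrogen, affects the read-out: 3-(dimethylamino)propyl in place of 3-aminoprop-1-en-1-yl gives a number 15 percentage points higher from compound 3 to compound 4 (beyond the scatter). Within the data shown here, this is the first step between compounds that differ in one place, so the earlier compounds could not show the effect of a single exchange. Nothing measured here accounts for the size or direction of this step.

The exchange removes the double bond and the hydrogen-bond donor and adds heavy atoms all at once, so the compounds shown do not tell which of these differences goes with the higher number. A saturated chain ending in a primary amine, or one ending in a methylamino group, on the core of compound 4 would begin to separate them.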